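The compounds below may be only part of what the source reports. "The series", "measured", "known", "first", "only" and "open" are said of these compounds alone.

Compound 1 `CC[C@H](C)[C@H](N)CN(C(=O)[C@@H]1C[C@H]1c1ccccc1)c1ccc(-c2ccccc2)cc1` in a functional assay for agonist activity at G protein-coupled receptor 88 (Homo sapiens), read by HTRF and cAMP accumulation (on this read-out higher numbers stand for an effect only at larger amounts of compound and lower numbers for an effect already at smaller amounts), gives 230 nM; 800 nM (2 entries).
Compound 2 `CC[C@H](C)[C@H](N)CN(C(=O)[C@@H]1C[C@H]1c1ccccc1F)c1ccc(-c2ccccc2)cc1` in this assay gives 650 nM.

The two entries for compound 1 spread across a range that is wider than the usual scatter of repeated measurements (the several entries of compound 1 in this assay, 230 nM; 800 nM (2 entries)), so the figure for compound 1 is itself uncertain. Compound 2 has only one number in this assay, alongside a further entry that gives no single number; that one value places compound 2 within the span covered by compound 1, and the two cannot be put in order on what is shown.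

Compound 3 `CC[C@H](C)[C@H](N)CN(C(=O)[C@@H]1C[C@H]1c1cccc(C#N)c1)c1ccc(-c2ccccc2)cc1` has not yet been measured. It differs from compound 2 in one place: 3-cyanophenyl in place of 2-fluorophenyl on a saturated ring carbon. Among the measured compounds shown here, no measured pair shows what this kind of change does in this assay, so the expectation rests on the single value of compound 2 alone. The step is expected to be small, in no definite direction and not beyond the scatter, giving an expected step of a 1.1-fold higher number from compound 2 to compound 3 (0.03 log units; within the scatter). Compound 3 is accordingly estimated at 700 nM, with an expected range from 200 nM to 2500 nM.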

Compound 3, half-maximal effective concentration: 1600 nM
For compound 3 the middle estimate is 2.3-fold (0.36 log units) below the measured one; the measured number falls inside the stated range.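

In this assay, the replacement of 2-fluorophenyl by 3-cyanophenyl on a saturated ring carbon of the three-membered ring gives a 2.5-fold higher number from compound 2 to compound 3 (0.39 log units; beyond the scatter), the first step shown at this position and one that lies beyond the scatter, though modestly. The result therefore shows that the number responds to what this ring carbon carries, while compound 3 still gives a single value of 1600 nM, so the nitrile-bearing group does not remove the read-out. Whether either substituent moves the number relative to the plain phenyl of compound 1 stays unsettled, as the reference compound is itself loosely fixed: the several entries of compound 1 in this assay, 230 nM; 800 nM (2 entries).

The step from compound 2 to compound 3 changes both the substituent and its ring position at once, so the compounds shown leave open whether the nitrile, the loss of fluorine or the new position accounts for it. A 3-fluorophenyl or a 2-cyanophenyl group would separate these, and a 3-aminophenyl or 3-methoxyphenyl group would show whether the trend extends beyond the nitrile.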